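The compounds below may be only part of what the source reports. "The series", "measured", "known", "first", "only" and "open" are said of these compounds alone.

Compound 1 `COc1ccc(NC(=O)CCCCCCNC(=O)C(O)(O)C(F)(F)F)cc1`: 4520 nM
Compound 2 `O=C(CCCCCCNC(=O)C(O)(O)C(F)(F)F)Nc1nc2ccccc2o1`: 3450 nM
Compound 3 `COc1ccccc1NC(=O)CCCCCCNC(=O)C(O)(O)C(F)(F)F`: 10100 nM

These values come from a functional assay on HCT-116 cells (Homo sapiens) for inhibition, read by colorimetric assay, with a stated time of 3 days; on this read-out lower numbers stand for stronger inhibition and higher numbers for weaker inhibition. Compound 1 has one neighbour within the scatter and one clearly apart: a 1.3-fold lower number from compound 1 to compound 2 (0.12 log units; within the scatter), and a 2.2-fold higher number from compound 1 to compound 3 (0.35 log units; beyond the scatter).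

Compound 4 `O=C(CCCCCCNC(=O)C(O)(O)C(F)(F)F)Nc1ccc(-c2ccccc2)cc1` carries phenyl in place of methoxy on an aromatic carbon. Among the measured compounds shown here, no measured step makes this exact swap. The nearest evidence is the changes to the group on the amide-type nitrogen, and the largest of those is only modest: a 2.9-fold higher number from compound 2 to compound 3 (0.47 log units; beyond the scatter). They give no clear direction, so no step beyond the scatter is expected.

The estimated step is a 1.1-fold lower number from compound 1 to compound 4 (0.05 log units; within the scatter).

Compound 4 is expected at 4000 nM, with an estimated range of 1700 nM to 9500 nM.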

Compound 4, half-maximal inhibitory concentration: 4730 nM
Beside the measured number, compound 4's estimate is 1.2-fold (0.07 log units) below it, and the stated range covers the measured number.
By their numbers in this assay, from the lowest: compounds 2, 1 and 4 (each within the scatter of the next); then compound 3.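

In this assay, the place on the aromatic ring para to a large group accepts phenyl in place of methoxy with a 1.0-fold higher number from compound 1 to compound 4 (0.02 log units; within the scatter) and no change beyond the scatter. Six heavy atoms and a second six-membered aromatic ring replace two heavy atoms and the one hydrogen-bond acceptor of methoxy, yet the read-out stays level. No measurement shown explains why these two compounds read alike.

As far as these compounds go, whether this tolerance extends to an amine or a carboxylic acid at the same place remains open.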